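Bringing a Bromine-Bearing Ring Back onto the Amide Tail

This account rests on a few compounds, and the source may have more. Where it says the series, first, only, none or still open, it means among the compounds named here.

Compound 2 `CCCn1c(=O)c2nc(-c3ccc(OCC(=O)NCCNC(=O)CCCCC(C)=O)cc3)[nH]c2n(CCC)c1=O` gives 44 nM in an assay on brain for binding affinity to adenosine receptor A1 (Rattus norvegicus), read by radioligand binding (on this read-out higher numbers stand for weaker inhibition and lower numbers for stronger inhibition), the highest of the two numbers measured. Compound 1 `CCCn1c(=O)c2nc(-c3ccc(OCC(=O)NCCN=C(S)Nc4ccc(Br)cc4)cc3)[nH]c2n(CCC)c1=O` gives 7.26 nM. Among the compounds with values here, the only step available, a 6.1-fold higher number from compound 1 to compound 2 (0.78 log units; beyond the scatter), exchanged a bromine-bearing aromatic group for an open chain, and this assay rose beyond the scatter. Compound 3 `CCCn1c(=O)c2nc(-c3ccc(OCC(=O)NCCNC(=O)c4ccc(CBr)cc4)cc3)[nH]c2n(CCC)c1=O` moves the other way: 4-(bromomethyl)phenyl in place of 4-acetylbutyl on a carbonyl carbon. As that change restores an aromatic ring carrying bromine at the amide tail, the expected step is a 3.7-fold lower number from compound 2 to compound 3 (0.56 log units; beyond the scatter). Compound 3 is therefore estimated at 12 nM, with a range from 4 nM to 40 nM.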

Compound 3, inhibition constant: 11.5 nM
Beside the measured number, compound 3's estimate is 1.0-fold (0.02 log units) above it; low and high end bracket the measured number.
By their numbers in this assay, from the lowest: compounds 1 and 3 (each within the scatter of the next); then compound 2.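

In this assay, 4-(bromomethyl)phenyl in place of 4-acetylbutyl on the carbonyl carbon gives a 3.8-fold lower number from compound 2 to compound 3 (0.58 log units; beyond the scatter) in the sense of a real gain, so the step seen earlier can now be read from the reverse direction with a different aromatic tail. Two quite different tails that each hold a bromine-bearing aromatic ring read alike, with a 1.6-fold higher number from compound 1 to compound 3 (0.20 log units; within the scatter) and no order between them. No measurement here says why these numbers move. Going by these compounds, whether the aromatic ring or the bromine carries the step stays open; a plain phenyl on that carbonyl carbon would help tell them apart.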